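This account rests on a few compounds, and the source may have more. Where it says the series, first, only, none or still open, it means among the compounds named here.

Compound 1 `COc1ccc(-c2c(Br)c(=O)c3c(OC)cc(OC)cc3n2S(=O)(=O)c2ccc(OC)cc2)cc1`, compound 2 `COc1ccc(-c2cc(=O)c3c(OC)cc(OC)cc3n2S(=O)(=O)c2ccc([N+](=O)[O-])cc2)cc1` and compound 3 `COc1ccc(-c2cc(=O)c3c(OC)cc(OC)cc3n2S(=O)(=O)c2c(C(C)C)cc(C(C)C)cc2C(C)C)cc1` share one core and were tested in a functional assay on HepG2 cells (Homo sapiens) for antiproliferative activity, with a stated time of 72 h; on this read-out higher numbers stand for an effect only at larger amounts of compound and lower numbers for an effect already at smaller amounts. For compound 1 this assay returned only a limit, > 20000 nM, and not a number. Compound 2 likewise reached only a limit, > 29300 nM. Compound 3 also stopped at a limit, > 341000 nM. Compound 2 therefore stands nowhere that a number would fix: its own result is a limit, and the two further results shown are limits as well, so that no step between measured compounds can be drawn and no order among the three can be read.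

Compound 4 `COc1ccc(-c2cc(=O)c3c(OC)cc(OC)cc3n2S(=O)(=O)c2ccc(Br)s2)cc1` is the unmeasured member of the set. It differs from compound 2 in a single place: 5-bromothiophen-2-yl in place of 4-nitrophenyl on a sulfonyl sulfur. Within the data shown here, with compound 2 and both other compounds sitting at limits, there is no measured step from which a direction for this change could be taken, and no effect beyond the usual scatter is expected; the expected step from compound 2 to compound 4 is a step that the limit leaves unreadable from compound 2 to compound 4. Compound 4 is accordingly estimated at 30000 nM, with a plausible range from 8000 nM to 150000 nM, and a limit rather than a number is the expected outcome.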

Compound 4, half-maximal effective concentration: > 48200 nM
Compound 4: only a limit was reported (the forecaster's own chance of this, stated with the estimate: 80%); middle value at least 1.6-fold (0.20 log units) away from the limit.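

In this assay compound 4 gave only a limit, > 48200 nM. Among these compounds, compound 2 also stands at a limit, so no step from compound 2 to compound 4 can be read. The compounds shown leave open whether 5-bromothiophen-2-yl in place of 4-nitrophenyl on a sulfonyl sulfur changes the result, and at what concentration any of them would show an effect.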